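Removing the chloro group from an inactive lactone anilide

The compounds below may be only part of what the source reports. "The series", "measured", "known", "first", "only" and "open" are said of these compounds alone.

Compound 1 `O=C(CNc1ccccc1F)N[C@H]1CCOC1=O`: in a functional assay on DU-145 cells (Homo sapiens) for antiproliferative activity, read by MTT assay, with a stated time of 72 h (a lower number here means a stronger inhibitor, a higher number a weaker inhibitor), compound 1 reports only a limit, > 64000 nM.
Compound 2 `O=C(CNc1cccc(Cl)c1)N[C@H]1CCOC1=O`: in this assay compound 2 likewise reports only a limit, > 64000 nM.

The two measured compounds share the same core and differ only in the substituent on the six-membered aromatic ring of carbon only, fluoro in compound 1 and chloro in compound 2. Neither gives a number; both sit at the limit of > 64000 nM in this assay, at which 2 of the 2 values shown sit. Among the compounds with values here, compound 2 therefore stands at the edge of what this assay can report, with no measured potency at all, and no step between measured compounds exists to show how a change on this ring moves the read-out.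

Compound 3 `O=C(CNc1ccccc1)N[C@H]1CCOC1=O` differs from compound 2 by hydrogen in place of chloro on an aromatic carbon. With compound 1 also at > 64000 nM and compound 2 at > 64000 nM, no shift beyond the scatter is expected from this small change. The step of a number no higher from compound 2 to compound 3 (the limit leaves the size open) is expected to be none beyond the scatter. Compound 3 is estimated at 64000 nM, in the range 20000 nM to 200000 nM, most likely again reported only as a limit.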

Compound 3, half-maximal inhibitory concentration: > 64000 nM
Compound 3 was reported as a limit (the forecaster's own chance of this, stated with the estimate: 80%); the middle value lies on the limit itself.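

No new step can be read from compound 3: the steps to it from compound 1 and compound 2 stay unreadable, because each of the three compounds gives only a limit: the limit of > 64000 nM in this assay, at which 3 of the 3 values shown sit.

The compounds shown leave open whether fluoro, chloro or hydrogen on the aromatic ring makes any difference in this assay.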